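The source may report more compounds than this note shows. Statements on the series, on what has been measured and on what is new or still open speak of the compounds shown alone.

Working notes on the series. In a functional assay on A549 cells (Homo sapiens) for cytotoxicity, read by MTT assay (a higher number here means a weaker inhibitor, a lower number a stronger inhibitor), compound 1 `CC1(C)CCc2c(C3CCc4ccc(O)cc4O3)ccc(O)c2O1` gives > 100000 nM, which is a limit and not a number. Compound 2 `CC1(C)CCc2c([C@@H]3CCc4ccc(O)cc4O3)ccc(O)c2O1` gives > 100000 nM, again a limit, so its standing is known only as the limit of > 100000 nM in this assay, at which 2 of the 2 values shown sit. Going by the values given here, the one measured step, a step that the two limits leave unreadable from compound 1 to compound 2, has no readable size, and what separates its two ends is the fact that one of compounds 1 and 2 is drawn with a defined configuration and the other without, at the place where they differ. Compound 3 `CC1(C)CCc2c([C@H]3CCc4ccc(O)cc4O3)ccc(O)c2O1` is the next structure: the two compounds have the same atoms and bonds and differ only in configuration as drawn: 1 of 1 stereo elements differ; a stereocentre at a saturated ring carbon is drawn S in compound 2 and R in compound 3, so a stereocentre at a saturated ring carbon is drawn S in compound 2 and R in compound 3. Among the compounds with values here, only that unreadable step bears on this change, and it gives no sign of a gain in either direction. The expected change, a number no higher from compound 2 to compound 3 (the limit leaves the size open), is none beyond the scatter. In this assay, compound 3 is expected to sit near 100000 nM, with an estimated range of 40000 nM to 200000 nM, and most likely to be reported only as a limit.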

Compound 3, half-maximal inhibitory concentration: > 100000 nM
Compound 3 was reported as a limit; the forecaster's own chance of this, stated with the estimate: 85%; the middle value lies on the limit itself.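

In this assay compound 1, compound 2 and compound 3 are all reported only as limits, and none of the steps among them can be read. Left open is whether the configuration at the saturated ring carbon makes any difference in this assay.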